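Cytotoxicity limits in the series: compound 2 to compound 3

This account rests on a few compounds, and the source may have more. Where it says the series, first, only, none or still open, it means among the compounds named here.

Measured in an ADME assay on MT4 cells (Homo sapiens) for cytotoxicity, read by XTT assay, with a stated time of 5 days; a higher number here means that more compound is tolerated, a lower number that less compound is tolerated:
compound 1 `CNC(=O)[C@@H](NC(=O)[C@@](O)(CCCN(Cc1ccc(Br)cc1)NC(=O)[C@@H](NC(=O)OC)C(C)(C)C)Cc1ccccc1)C(C)C`: > 10000 nM
compound 2 `CNC(=O)[C@@H](NC(=O)[C@@](O)(CCCN(Cc1ccc(-c2ccccc2)cc1)NC(=O)[C@@H](NC(=O)OC)C(C)(C)C)Cc1ccccc1)C(C)(C)C`: > 50000 nM

Compound 2 stands at > 50000 nM, which is a limit and not a number. Compound 1 also stands at a limit, > 10000 nM. Within the data shown here, with only these two limits, no number is available for either compound and no step between them can be read.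

Compound 3 `CNC(=O)[C@@H](NC(=O)[C@@](O)(CCCN(Cc1ccc(-c2ccncc2)cc1)NC(=O)[C@@H](NC(=O)OC)C(C)(C)C)Cc1ccccc1)C(C)(C)C` is the next compound to be measured. It carries pyridin-4-yl in place of phenyl on an aromatic carbon, para to a large group, so that 4-phenylphenyl becomes 4-(pyridin-4-yl)phenyl: pyridin-4-yl in place of phenyl on an aromatic carbon. Among the measured compounds shown here, no measured pair shows this change. The expectation therefore rests on compound 2 at > 50000 nM, and no change beyond the usual scatter is expected in this assay, in either direction. The expected size of the change is an at least 1.2-fold lower number from compound 2 to compound 3 (0.09 log units; that floor lies within the scatter). A limit rather than a number is the likelier report. Compound 3 is estimated at 40000 nM, with an expected range from 18000 nM to 90000 nM.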

Compound 3, half-maximal cytotoxic concentration: > 50000 nM
Compound 3: no number, only a limit; the forecaster's own chance of this, stated with the estimate: 65%; middle value at least 1.2-fold (0.09 log units) from the limit.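

In this assay, among these compounds, compound 2 and compound 3 each report a limit and not a number, and no step between them can be read. The compounds shown leave open what number any of them would reach in this assay, and whether pyridin-4-yl in place of phenyl changes it at all.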